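Swapping the thiophene substituent on a shared core

The source may report more compounds than this note shows. Statements on the series, on what has been measured and on what is new or still open speak of the compounds shown alone.

Of the compounds shown here, three that share one core have been tested in an assay on isolated protein for inhibition of DNA topoisomerase 1 (Homo sapiens), with a stated time of 30 min, tested at 100 uM; on this read-out higher numbers stand for more inhibition at the one concentration tested (going by the name of the read-out) and lower numbers for less inhibition. Compound 1 `Cc1ccsc1-c1cc(-c2ccoc2)cc(-c2ccc(Cl)cc2)n1` gives 85.9% and stands highest of the three, the others lying beyond the scatter below it. Within the data shown here, compound 2 `Clc1ccc(-c2cc(-c3ccco3)cc(-c3ccc(Cl)s3)n2)cc1` gives 53.1%, and compound 3 `Clc1cccc(-c2cc(-c3ccoc3)cc(-c3ccc(Cl)s3)n2)c1` gives 2.1%; each of these differs from compound 1 in more than one place, so no single step between measured compounds can be read off.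

The next compound, compound 4 `Clc1ccc(-c2cc(-c3ccoc3)cc(-c3ccc(Cl)s3)n2)cc1`, is reached from compound 1 by one change, (5-chlorothiophen-2-yl in place of 3-methylthiophen-2-yl on an aromatic carbon). The group that enters is the same 5-chlorothiophen-2-yl group carried by compound 2 and compound 3, while the 4-chlorophenyl and furan-3-yl groups of compound 1 are kept.

Since compound 2 and compound 3, both bearing the 5-chlorothiophen-2-yl group, sit well below compound 1, a downward step is expected, of the size a number 40.9 percentage points lower from compound 1 to compound 4 (beyond the scatter), beyond the scatter. Compound 4 is therefore estimated to give 45% in this assay, within a range from 10% to 80%.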

Compound 4, a percentage reported as inhibition, at one concentration (the size of the read-out at that concentration, not a potency): 2.3%
For compound 4 the middle estimate is 42.7 percentage points above the measured one, and the stated range ends above it.
By their numbers in this assay, from the lowest: compounds 3 and 4 (each within the scatter of the next); then compound 2; then compound 1.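

In this assay, 5-chlorothiophen-2-yl in place of 3-methylthiophen-2-yl on the carbon next to the ring nitrogen gives a number 83.6 percentage points lower from compound 1 to compound 4 (beyond the scatter) and removes most of the inhibition, so a single change at this position is now seen to have a large effect on the read-out. With 5-chlorothiophen-2-yl held fixed, the other two single changes can also be read: furan-3-yl in place of furan-2-yl gives a number 50.8 percentage points lower from compound 2 to compound 4 (beyond the scatter) and is also a large step, whereas 4-chlorophenyl in place of 3-chlorophenyl gives a number 0.2 percentage points higher from compound 3 to compound 4 (within the scatter) and shows no difference that can be told from the scatter. Nothing available explains any of these steps.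

The step from compound 1 to compound 4 changes both the substituent on the thiophene and where it sits, so the compounds shown do not tell whether losing the methyl, gaining the chlorine or moving the substituent matters most. They also leave open how an unsubstituted thiophen-2-yl, or a thiophene carrying an amine or a carboxylic acid, would read at this position.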